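The source may hold more compounds than are shown below. What is called first, only, known or untested is meant among the compounds shown, and "the series" means these compounds.

Three compounds have been measured in a functional assay with Alpha-1D adrenergic receptor (Homo sapiens) as the target, read by calcium flux; a lower number here means a smaller maximal response, a higher number a larger maximal response:
compound 2 `c1ccc(-c2cn[nH]c2)c(NCC2=NCCN2)c1` gives 62%;
compound 1 `CCn1cccc1-c1ccccc1NCC1=NCCN1` gives 0%;
compound 3 `CCn1cc(-c2ccccc2NCC2=NCCN2)cn1` gives 0%.

Compound 2 stands highest of the three; compound 1 and compound 3 both lie far below it, beyond the usual scatter. Compound 4 `Cn1nccc1-c1ccccc1NCC1=NCCN1` has not yet been measured. Compared with compound 2 it carries 1-methyl-1H-pyrazol-5-yl in place of 1H-pyrazol-4-yl on an aromatic carbon. Among the compounds with values here, the one measured step that bears on this change is ethyl in place of hydrogen on an aromatic nitrogen, which gave a number 62 percentage points lower from compound 2 to compound 3 (beyond the scatter), a fall to no measurable response. Compound 1, which also carries an ethyl on an aromatic nitrogen, gives 0%. With both compounds that carry an alkyl group on the aromatic nitrogen showing no response, the methyl group entering in compound 4 is expected to lower the maximal response in this assay by a large step, a number 54 percentage points lower from compound 2 to compound 4 (beyond the scatter). Compound 4 is therefore estimated at 8%, within a range of 0% to 35%.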

Compound 4, largest response reached (reported as maximal response), in percent of the reference or control that the assay uses: 0%
The estimate for compound 4 lay 8 percentage points above the measured number, and the stated range covers the measured number.
By their numbers in this assay, from the lowest: compounds 1, 3 and 4 (each within the scatter of the next); then compound 2.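

In this assay the entry of 1-methyl-1H-pyrazol-5-yl brings a number 62 percentage points lower from compound 2 to compound 4 (beyond the scatter) and so shows that the loss of response is not confined to an ethyl group: a group with a methyl on the ring nitrogen also ends at no measurable response. Among the four compounds, only compound 2 keeps a hydrogen on the nitrogen of its five-membered ring and only compound 2 gives a response, with no compound going against this pattern. Nothing available explains this loss of response.

This change moves the point of attachment and adds the methyl at once, so the two effects cannot be separated. A 1H-pyrazol-5-yl or a 1-methyl-1H-pyrazol-4-yl group on the same carbon would tell them apart.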